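The compounds below may be only part of what the source reports. "The series", "measured", "known", "first", "only" and "open" are said of these compounds alone.

Measured compounds:
- Compound 1 `C[C@@H](NCC1CCN(CCCc2c[nH]c3ccc(-n4cnnc4)cc23)CC1)c1ccccc1` in an assay on CHO cells for displacement of a labelled ligand from 5-hydroxytryptamine receptor 1B (Homo sapiens) (a lower number here means a stronger inhibitor, a higher number a weaker inhibitor), gives 14 nM
- Compound 2 `O[C@H]1Cc2ccccc2C1NC1CCN(CCCc2c[nH]c3ccc(-n4cnnc4)cc23)CC1` gives 300 nM
- Compound 3 `c1ccc(CNCC2CCN(CCCc3c[nH]c4ccc(-n5cnnc5)cc34)CC2)cc1` gives 28 nM

Compound 3 stands second highest of the three numbers; its nearest neighbour is compound 1, a step within the scatter, and its furthest is compound 2, a large step.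

Compound 4 `CC(C)=CCCN(C)C1CCN(CCCc2c[nH]c3ccc(-n4cnnc4)cc23)CC1` is not yet measured. It differs from compound 3 by methyl(4-methylpent-3-en-1-yl)amino in place of (benzylamino)methyl on a saturated ring carbon.

Among the compounds with values here, two measured steps bear on changes at this ring carbon. The step of an 11-fold lower number from compound 2 to compound 3 (1.03 log units; beyond the scatter) and the step of a 21-fold higher number from compound 1 to compound 2 (1.33 log units; beyond the scatter) both show that exchanging the group on this carbon moves the number by a large amount, while a 2.0-fold higher number from compound 1 to compound 3 (0.30 log units; within the scatter) shows that a small change at the chain carbon stays within the scatter. In compound 4 the six-membered aromatic ring leaves and an open chain without a hydrogen-bond donor enters, a change of the larger kind. A large step upward is therefore expected, toward the weaker end of the series.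

Compound 4 is estimated at 200 nM, between 40 nM and 1000 nM, an expected step of a 7.1-fold higher number from compound 3 to compound 4 (0.85 log units; beyond the scatter).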

Compound 4, half-maximal inhibitory concentration: 24 nM
Beside the measured number, compound 4's estimate is 8.3-fold (0.92 log units) above it; the whole stated range lies above it.
By their numbers in this assay, from the lowest: compounds 1, 4 and 3 (each within the scatter of the next); then compound 2.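

At this ring carbon, the aromatic ring of the leaving group is not needed to hold the number in this assay: methyl(4-methylpent-3-en-1-yl)amino, with no ring and no hydrogen-bond donor, gives a 1.2-fold lower number from compound 3 to compound 4 (0.07 log units; within the scatter), and against ((1-phenylethyl)amino)methyl it gives a 1.7-fold higher number from compound 1 to compound 4 (0.23 log units; within the scatter). Only compound 2 stands apart, with a 13-fold lower number from compound 2 to compound 4 (1.10 log units; beyond the scatter), so exchanging the group on this carbon does not in itself bring a large step, and the large steps seen so far all involve (2-hydroxy-2,3-dihydro-1H-inden-1-yl)amino. Nothing available explains this tolerance or the separate place of compound 2.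

The methyl on the nitrogen and the double bond enter together, so neither can be read alone. A saturated 4-methylpentyl chain or a carboxylic acid on this ring carbon would test how far the tolerance extends.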